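Swapping the ester for an ether on a shared naphthoquinone scaffold

A few compounds are considered here, and "the series" means these few. Any claim that something is new, unique, unknown or untested is made for them only; others in the source may bear on it.

Of the compounds shown here, two have been tested so far in a functional assay on HeLa cells (Homo sapiens) for cytotoxicity, read by MTT assay; a lower number here means a stronger inhibitor, a higher number a weaker inhibitor. Compound 1 `CCC(CO[C@H](CC=C(C)C)C1=CC(=O)c2c(O)ccc(O)c2C1=O)OC(C)=O` gives 44000 nM in this assay. Compound 2 `CCC(O)(CC)CC(=O)O[C@H](CC=C(C)C)C1=CC(=O)c2c(O)ccc(O)c2C1=O` gives 52000 nM in this assay, the higher of the two numbers, though the change a 1.2-fold higher number from compound 1 to compound 2 (0.07 log units; within the scatter) stays within the scatter, so the two cannot be ranked against each other.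

Compound 3 `CCC(CO[C@H](CC=C(C)C)C1=CC(=O)c2c(O)ccc(O)c2C1=O)OC` has not been measured. Its difference from compound 2 is 2-methoxybutyl in place of (2-ethyl-2-hydroxybutyl)carbonyl on an oxygen on a saturated carbon. Among the compounds with values here, the only measured step, a 1.2-fold higher number from compound 1 to compound 2 (0.07 log units; within the scatter), also altered the group on that same oxygen, and it moved the number by less than the scatter. With nothing else to draw on, the expectation for this assay is that the new change will also stay within the scatter, so the step of a 1.1-fold lower number from compound 2 to compound 3 (0.04 log units; within the scatter) is expected to be small and without a clear direction. Compound 3 is therefore estimated at 47000 nM in this assay, with a plausible range from 20000 nM to 110000 nM.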

Compound 3, half-maximal inhibitory concentration: 63500 nM
The estimate for compound 3 lay 1.4-fold (0.13 log units) below the measured number; the measured number falls inside the stated range.
By their numbers in this assay, from the lowest: compounds 1, 2 and 3 (each within the scatter of the next).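

In this assay, replacing (2-ethyl-2-hydroxybutyl)carbonyl with 2-methoxybutyl on this oxygen removes the hydroxyl and the carbonyl and shortens the group, yet it gives a 1.2-fold higher number from compound 2 to compound 3 (0.09 log units; within the scatter), and the smaller change of methyl in place of acetyl gives a 1.4-fold higher number from compound 1 to compound 3 (0.16 log units; within the scatter). All three pairs of compounds now lie within the scatter of one another, so this oxygen has carried an ester link in compound 2 and ether links in compound 1 and compound 3, with and without an acetyl group, without any difference that can be read in this cell assay. No measurement at hand explains why the numbers stay so close.

From the compounds shown here alone, what remains open is whether a group of another kind on this oxygen, such as an amine, a carboxylic acid or an aromatic ring, would move the number beyond the scatter. The free alcohol, with only hydrogen on this oxygen, is also not among these compounds, so the effect of removing the side group altogether remains unknown.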